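The source may report more compounds than this note shows. Statements on the series, on what has been measured and on what is new or still open speak of the compounds shown alone.

Compound 1 `CC(C)(C)c1ccc(CNCCCNS(=O)(=O)c2cc(C(F)(F)F)cc(C(F)(F)F)c2)cc1`: 2300 nM
Compound 2 `COc1ccc(CNCCCNS(=O)(=O)c2cc(C(F)(F)F)cc(C(F)(F)F)c2)cc1OC`: 3500 nM

In a functional assay on HPAC cells (Homo sapiens) for inhibition, read by MTT assay, with a stated time of 72 h (on this read-out lower numbers stand for stronger inhibition of growth and higher numbers for weaker inhibition of growth), compound 2 gives 3500 nM, the higher of the two numbers, while compound 1 gives 2300 nM. For the measured compounds named here, the one measured step between them, a 1.5-fold higher number from compound 1 to compound 2 (0.18 log units; within the scatter), exchanges one aryl group for another at the same position and stays within the scatter. Compound 3 `O=S(=O)(NCCCNCc1ccc(Cl)c(C(F)(F)F)c1)c1cc(C(F)(F)F)cc(C(F)(F)F)c1` has not yet been measured. It differs from compound 2 by 4-chloro-3-(trifluoromethyl)phenyl in place of 3,4-dimethoxyphenyl on a saturated chain carbon bound to an amine nitrogen. Going by the values given here, the only step that bears on this change is the aryl swap from compound 1 to compound 2, which moved the number by no more than the scatter, and the new aryl group is a third variation at the same position. No step beyond the scatter is therefore expected in this assay, in either direction. Compound 3 is expected to give 2500 nM, between 900 nM and 7000 nM. The step this estimate implies is expected to be a 1.4-fold lower number from compound 2 to compound 3 (0.15 log units; within the scatter).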

Compound 3, concentration for 50% growth inhibition: 3000 nM
The estimate for compound 3 lay 1.2-fold (0.08 log units) below the measured number, and the stated range covers the measured number.
By their numbers in this assay, from the lowest: compounds 1, 3 and 2 (each within the scatter of the next).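

In this assay, the third aryl group gives a 1.2-fold lower number from compound 2 to compound 3 (0.07 log units; within the scatter), and set against the first it gives a 1.3-fold higher number from compound 1 to compound 3 (0.12 log units; within the scatter). The 4-chloro-3-(trifluoromethyl)phenyl group brings chlorine and fluorine where 3,4-dimethoxyphenyl has oxygen and 4-(tert-butyl)phenyl has neither, so these three compounds show that quite different substituted phenyl groups on a saturated chain carbon bound to an amine nitrogen can give numbers that cannot be told apart. Nothing available explains this flat result.

As far as these compounds go, it remains open whether this tolerance extends beyond substituted phenyl groups, for example to a pyridine ring, a cyclohexyl ring or a plain methyl group at the same place. The compounds also leave open how a carboxylic acid on the aryl ring or a longer chain in the shared core would read.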